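Adding one methyl at the far end of the chain

The compounds below may be only part of what the source reports. "The series", "measured", "known", "first", "only" and "open" are said of these compounds alone.

Measured so far in a functional assay on the whole organism for agonist activity, with Mus musculus as the target (a lower number here means that less compound is needed, a higher number that more compound is needed for the effect), and still to be measured:
- compound 1 `COC(=O)N(C)CC#CCn1ccnc1` gives 2 mg/kg
- compound 2 `COC(=O)N(C)C(C)C#CCn1ccnc1` gives 6.6 mg/kg
- compound 3 `CCOC(=O)N(C)C(C)C#CCn1ccnc1` has no value yet

Of the two measured compounds, compound 2 stands highest, with 6.6 mg/kg in this assay, so more of it is needed for the effect. Compound 3 differs from compound 2 in one place: methyl in place of hydrogen on a saturated chain carbon bound to an oxygen next to a carbonyl group. In words, methyl takes the place of hydrogen on a saturated chain carbon bound to an oxygen next to a carbonyl group, turning methoxycarbonyl into ethoxycarbonyl.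

Going by the values given here, only one measured step bears on this: a 3.3-fold higher number from compound 1 to compound 2 (0.52 log units; beyond the scatter). That step also added a methyl, but on a saturated chain carbon bound to an amide-type nitrogen and a triple-bonded carbon. Among the compounds with values here, no measured step touches the methoxycarbonyl end, so this single step is weak guidance. A modest rise in the number is expected, though a change in the other direction cannot be ruled out. The estimate therefore means a 1.5-fold higher number from compound 2 to compound 3 (0.18 log units; within the scatter) in this assay as the expected step. Compound 3 is expected at 10 mg/kg (estimated range 3.5 mg/kg to 30 mg/kg).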

Compound 3, dose for half-maximal effect: > 100 mg/kg
Compound 3: only a limit was reported; the forecaster's own chance of this, stated with the estimate: 10%; middle value at least 10-fold (1.00 log units) from the limit.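

In this assay, turning methoxycarbonyl into ethoxycarbonyl gives an at least 15-fold higher number from compound 2 to compound 3 (1.18 log units; beyond the scatter), so a change of a single methyl at this end of the molecule can decide whether the effect is reached at all within the doses reported. Going by these compounds alone, the earlier compounds gave no sign of this: the only step known before, with a methyl on the saturated chain carbon bound to an amide-type nitrogen and a triple-bonded carbon, was a 3.3-fold higher number from compound 1 to compound 2 (0.52 log units; beyond the scatter), whereas the same kind of addition on the saturated chain carbon bound to an oxygen next to a carbonyl group is a large step. The result for compound 3 is a limit of the assay and not a number, so the step shows only a minimum size for the change: the limit of > 100 mg/kg in this assay, at which 1 of the 3 values shown sits.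

As far as these compounds go, the two added methyls stand together only in compound 3, so it remains open whether ethoxycarbonyl would cost as much on the core of compound 1, which has no methyl on that chain carbon. Also open, from the compounds shown here alone, is how this end of the molecule responds to other groups, such as a longer chain like propoxycarbonyl or a carboxylic acid.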